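A few compounds are considered here, and "the series" means these few. Any claim that something is new, unique, unknown or untested is made for them only; others in the source may bear on it.

Measured compounds:
Compound 1, `OCCC#Cc1ccccc1C#Cc1ccccc1`, gives 11000 nM in a functional assay on K562 cells (Homo sapiens) for cytotoxicity; a higher number here means a weaker inhibitor of growth, a lower number a stronger inhibitor of growth.
Compound 2, `OCCCCC#Cc1ccccc1C#Cc1ccccc1`, gives 21100 nM in this assay.
Compound 3, `COc1cccc(C#Cc2ccccc2C#CCCCCO)c1`, gives 1800 nM in this assay.

Of these three numbers, compound 3 holds the lowest; compound 1 lies closest to it and compound 2 furthest, both separated from it by more than the scatter. The step from compound 1 to compound 2 changed the chain bearing the hydroxy group, and a 1.9-fold higher number from compound 1 to compound 2 (0.28 log units; within the scatter), so that change counts for nothing here. The step that matters came next: a 12-fold lower number from compound 2 to compound 3 (1.07 log units; beyond the scatter), which is the one large movement in the set.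

Compound 4, `OCCCCC#Cc1ccccc1C#Cc1cccc(C(F)(F)F)c1`, differs from compound 3 in that same place: trifluoromethyl in place of methoxy on an aromatic carbon. For the measured compounds named here, no measured step exchanges methoxy for trifluoromethyl, so the only guide is the step from compound 2 to compound 3, which shows that what sits on that aromatic carbon can move this assay a long way. Whether trifluoromethyl keeps the gain of methoxy or gives it back is not told by the data. The account therefore expects compound 4 to sit between compound 2 and compound 3, with a step of a 3.3-fold higher number from compound 3 to compound 4 (0.52 log units; beyond the scatter) as the estimate. Compound 4 is estimated at 6000 nM, with a range from 1500 nM to 25000 nM.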

Compound 4, concentration for 50% growth inhibition: 22500 nM
The estimate for compound 4 lay 3.8-fold (0.57 log units) below the measured number; the range from low to high includes it.
By their numbers in this assay, from the lowest: compound 3; then compounds 1, 2 and 4 (each within the scatter of the next, the first and the last beyond it).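

For the compounds shown here, compound 2 carries hydrogen on this aromatic carbon, meta to a large group, so the earlier compounds showed only that methoxy there lowers the number; they could not tell whether any added group would do the same. Trifluoromethyl shows that it does not: in this assay, exchanging methoxy for it gives a 13-fold higher number from compound 3 to compound 4 (1.10 log units; beyond the scatter) and so gives back the whole gain, while against hydrogen it gives a 1.1-fold higher number from compound 2 to compound 4 (0.03 log units; within the scatter) and leaves no measurable difference. Among the compounds shown, the low number is therefore tied to methoxy and not merely to having a substituent at this place, though nothing given here offers a reason for the contrast between these two groups.

Going by these compounds, whether other groups on this carbon, such as ethoxy, hydroxy or an amine, would keep the low number of compound 3 remains open, as does whether methoxy would act alike elsewhere on that ring. Also open, on these data alone, is whether methoxy would bring a similar step on the shorter chain of compound 1, or with a carboxylic acid in place of the hydroxy group that ends the chain.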